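The compounds below may be only part of what the source reports. "The series", "measured", "known", "first", "only" and "open" are said of these compounds alone.

Measured in an ADME assay on MT4 cells (Homo sapiens) for cytotoxicity, read by MTT assay, with a stated time of 96 h; on this read-out higher numbers stand for lower toxicity in this test and lower numbers for higher toxicity in this test:
- compound 1 `Cc1ccc(/N=N/c2ccc(NCCCN(C)C)cc2)cc1`: 17000 nM
- compound 2 `Fc1ccc(F)c(/N=N/Nc2cccc(C(F)(F)F)c2)c1`: > 100000 nM (a limit of the assay, not a number)
- compound 3 `CCOC(=O)N1CCN(/N=N/c2ccccc2)CC1`: 100000 nM

Compound 2 stands at the limit of > 100000 nM in this assay, at which 1 of the 3 values shown sits. It therefore gives no number of its own to start from.

The next compound to be read is compound 4 `CN(C)CCCN(/N=N/c1cc(F)ccc1F)c1cccc(C(F)(F)F)c1`, which has 3-(dimethylamino)propyl in place of hydrogen on a nitrogen on an aromatic ring. Among the measured compounds shown here, no pair of measured compounds isolates this change, so the expectation rests on a single comparison. Compound 1 also carries 3-(dimethylamino)propyl and gives 17000 nM. Compound 3 lacks that chain and gives 100000 nM. Three compounds cannot establish a pattern, and the cores differ. Even so, a move toward lower numbers in this assay, meaning higher toxicity in this test, is expected, and it should exceed the usual scatter. The expected step is an at least 5.0-fold lower number from compound 2 to compound 4 (0.69 log units; beyond the scatter). For compound 4 the estimated value is 20000 nM, with an expected range of 6000 nM to 60000 nM.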

Compound 4, half-maximal cytotoxic concentration: 16000 nM
Beside the measured number, compound 4's estimate is 1.3-fold (0.10 log units) above it; the measured number falls inside the stated range.
By their numbers in this assay, from the lowest: compounds 4 and 1 (each within the scatter of the next); then compound 3.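

In this assay, among the compounds shown here, placing 3-(dimethylamino)propyl in place of hydrogen on a nitrogen on an aromatic ring gives an at least 6.2-fold lower number from compound 2 to compound 4 (0.79 log units; beyond the scatter) and is the only step that isolates a single change. Substitution at this nitrogen alone is thus enough to move the number lower, meaning higher toxicity in this test, on the core shared by these two compounds. The true size of the step stays unknown because compound 2 carries a limit of the assay and not a number: the limit of > 100000 nM in this assay, at which 1 of the 4 values shown sits.

On these data alone, whether a shorter chain, a longer chain or a chain ending in a carboxylic acid at this nitrogen would give a similar step stays open. A single step on one core also leaves open whether the change would act the same way on other cores.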